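The source may hold more compounds than are shown below. What is called first, only, known or untested is meant among the compounds shown, and "the series" means these compounds.

Measured so far in a functional assay on MCF7 cells (Homo sapiens) for cytotoxicity, read by MTT assay, with a stated time of 48 h; on this read-out higher numbers stand for weaker inhibition and lower numbers for stronger inhibition:
- compound 1 `Cc1ccccc1-c1nnc(SCCn2c([N+](=O)[O-])cnc2C)o1` gives 15800 nM
- compound 2 `COc1ccc(-c2nnc(SCCn3c([N+](=O)[O-])cnc3C)o2)cc1` gives 10600 nM

Among the compounds with values here, compound 1 holds the higher of only two numbers, but its gap to compound 2 lies within the scatter, so the two values set no real order in this assay. Compound 3 `CCOc1ccccc1-c1nnc(SCCn2c([N+](=O)[O-])cnc2C)o1` is the next to be read. Its difference from compound 1 is ethoxy in place of methyl on an aromatic carbon, ortho to a large group.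

Within the data shown here, the one measured step with any bearing on this is a 1.5-fold lower number from compound 1 to compound 2 (0.17 log units; within the scatter). That step also changes the same aromatic ring, with 4-methoxyphenyl in place of 2-methylphenyl, but it is not the same substitution. It gives no sign of a strong response to such changes, although a single step is thin evidence. No shift beyond the scatter is therefore expected, in either direction.

The expected step is a 1.2-fold lower number from compound 1 to compound 3 (0.08 log units; within the scatter). For compound 3 the estimated value is 13000 nM, with an expected range from 6000 nM to 28000 nM.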

Compound 3, half-maximal inhibitory concentration: 25900 nM
Compound 3: the middle estimate sits 2.0-fold (0.30 log units) below what was measured, within the range that was stated.
By their numbers in this assay, from the lowest: compounds 2, 1 and 3 (each within the scatter of the next, the first and the last beyond it).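

In this assay ethoxy in place of methyl on an aromatic carbon, ortho to a large group, gives a 1.6-fold higher number from compound 1 to compound 3 (0.21 log units; within the scatter) and so stays within the scatter. Within the data shown here, this is the first reading in which only the group at this position changes, since the earlier step replaced the whole 2-methylphenyl with 4-methoxyphenyl. Going from 1 heavy atom and 0 hydrogen-bond acceptors in methyl to 3 heavy atoms and 1 hydrogen-bond acceptor in ethoxy therefore produces no shift that can be told from repeat variation in this assay, and no measurement is available that would explain this outcome.

From the compounds shown here alone, with only methyl and ethoxy to compare at this position, it remains open whether an amine, a carboxylic acid or a longer chain such as butoxy would also stay within the scatter or would move the number beyond it. Going by these compounds, it also remains open whether ethoxy would give the same result on a core carrying a different linker, for example a longer chain in place of the one that joins the two ring systems in compound 1.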